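Shifting the Chlorine: 4-Chlorophenyl to 2-Chlorophenyl

This account rests on a few compounds, and the source may have more. Where it says the series, first, only, none or still open, it means among the compounds named here.

- compound 1 `C=C1C(=O)[C@@]23C(=O)OC[C@]4([C@@H](OC(C)=O)CCC(C)(C)[C@H]4C=O)[C@@H]2CC[C@H]1[C@H]3OC(=O)c1ccc(Cl)cc1` gives 1730 nM
- compound 2 `C=C1C(=O)[C@@]23C(=O)OC[C@]4([C@@H](OC(C)=O)CCC(C)(C)[C@H]4C=O)[C@@H]2CC[C@H]1[C@H]3OC(=O)c1ccc([N+](=O)[O-])cc1` gives 1980 nM
- compound 3 `C=C1C(=O)[C@@]23C(=O)OC[C@]4([C@@H](OC(C)=O)CCC(C)(C)[C@H]4C=O)[C@@H]2CC[C@H]1[C@H]3OC(=O)c1ccc(C(F)(F)F)cc1` gives 5540 nM

In a functional assay on MGC-803 cells (Homo sapiens) for inhibition, read by MTT assay (a lower number here means a stronger inhibitor, a higher number a weaker inhibitor), compound 1 sits at the low end of the numbers, level with its nearest neighbour: a 1.1-fold higher number from compound 1 to compound 2 (0.06 log units; within the scatter). The other two steps are modest: a 3.2-fold higher number from compound 1 to compound 3 (0.51 log units; beyond the scatter) and a 2.8-fold higher number from compound 2 to compound 3 (0.45 log units; beyond the scatter).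

Compound 4 `C=C1C(=O)[C@@]23C(=O)OC[C@]4([C@@H](OC(C)=O)CCC(C)(C)[C@H]4C=O)[C@@H]2CC[C@H]1[C@H]3OC(=O)c1ccccc1Cl` keeps the shared core and changes one group: 2-chlorophenyl in place of 4-chlorophenyl on a carbonyl carbon. This places 2-chlorophenyl in place of 4-chlorophenyl on a carbonyl carbon. The measured steps only swap one group for another, and none moves the chlorine, so they guide the size of the step but not its direction. In this assay no step beyond the scatter is expected, and the estimated step is a 1.3-fold higher number from compound 1 to compound 4 (0.12 log units; within the scatter), slightly upward if real. For compound 4 the estimated value is 2300 nM, with an expected range from 1000 nM to 5300 nM.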

Compound 4, half-maximal inhibitory concentration: 1280 nM
Beside the measured number, compound 4's estimate is 1.8-fold (0.25 log units) above it; the range from low to high includes it.
By their numbers in this assay, from the lowest: compounds 4, 1 and 2 (each within the scatter of the next); then compound 3.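

Moving the chlorine tests where a group sits on the aromatic ring, not just which group it is, and in this assay the result is a 1.4-fold lower number from compound 1 to compound 4 (0.13 log units; within the scatter), so 2-chlorophenyl and 4-chlorophenyl cannot be told apart here. The step of a 1.5-fold lower number from compound 2 to compound 4 (0.19 log units; within the scatter) is also within the scatter, whereas a 4.3-fold lower number from compound 3 to compound 4 (0.64 log units; beyond the scatter) is beyond it, leaving compound 3 as the only one set apart. Nothing available explains these results.

Still open, from the compounds shown here alone, is how an amine or a carboxylic acid in place of the chlorine would read in this assay on this aromatic ring.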